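Moving from trimethoxyphenyl to 2-methoxyphenyl on the dienone chain

A few compounds are considered here, and "the series" means these few. Any claim that something is new, unique, unknown or untested is made for them only; others in the source may bear on it.

- compound 1 `COc1cc(/C=C/C(=O)/C=C/c2cccc3ccccc23)ccc1OCc1cn(CCOc2cc(=O)oc3ccccc23)nn1` gives 4480 nM
- compound 2 `COc1cc(/C=C/C(=O)/C=C/c2cc(OC)c(OC)c(OC)c2)ccc1OCc1cn(CCOc2cc(=O)oc3ccccc23)nn1` gives 820 nM
- compound 3 `COc1ccc(/C=C/C(=O)/C=C/c2ccc(OCc3cn(CCCOc4cc(=O)oc5ccccc45)nn3)c(OC)c2)cc1OC` gives 8510 nM

In a functional assay on THP-1 cells (Homo sapiens) for cytotoxicity, read by sulforhodamine B assay, with a stated time of 48 h (a higher number here means a weaker inhibitor, a lower number a stronger inhibitor), compound 2 holds the lowest of the three numbers, and its gaps to compound 1 and compound 3 both lie beyond the scatter.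

Compound 4 (`COc1ccccc1/C=C/C(=O)/C=C/c1ccc(OCc2cn(CCOc3cc(=O)oc4ccccc34)nn2)c(OC)c1`) has not yet been measured. It carries 2-methoxyphenyl in place of 3,4,5-trimethoxyphenyl on a double-bonded chain carbon bound to a double-bonded chain carbon.

For the measured compounds named here, the only measured step falls at that same place: a 5.5-fold lower number from compound 1 to compound 2 (0.74 log units; beyond the scatter) with 3,4,5-trimethoxyphenyl in place of naphthalen-1-yl. This modest step is a single case. On the evidence of compound 1 at 4480 nM a move away from 3,4,5-trimethoxyphenyl is expected to raise the number in this assay by a similar or smaller amount.

The expected step is a 3.0-fold higher number from compound 2 to compound 4 (0.48 log units; beyond the scatter) (an estimate resting on that one comparison). The estimated value for compound 4 is 2500 nM (expected range 1000 nM to 6000 nM).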

Compound 4, half-maximal inhibitory concentration: 7330 nM
For compound 4 the middle estimate is 2.9-fold (0.47 log units) below the measured one; the measured number lies above the stated range.
By their numbers in this assay, from the lowest: compound 2; then compounds 1, 4 and 3 (each within the scatter of the next).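

In this assay, the low number of compound 2 now looks specific to 3,4,5-trimethoxyphenyl on a double-bonded chain carbon bound to a double-bonded chain carbon, as 2-methoxyphenyl there gives an 8.9-fold higher number from compound 2 to compound 4 (0.95 log units; beyond the scatter). The two other groups at this place are not separated, with a 1.6-fold higher number from compound 1 to compound 4 (0.21 log units; within the scatter), so among these three aryl groups only 3,4,5-trimethoxyphenyl stands apart. The change from 3,4,5-trimethoxyphenyl to 2-methoxyphenyl lowers the count of heavy atoms and of hydrogen-bond acceptors, but no measurement here bears on what drives the step.

The compounds shown leave open whether the full set of three methoxy groups is required at this place or whether other substituted rings can match compound 2. A phenyl ring carrying a dimethylamino group or a carboxylic acid at this place would test how narrow that requirement is.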